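The source may hold more compounds than are shown below. What is called first, only, known or untested is meant among the compounds shown, and "the series" means these compounds.

Measured compounds:
Compound 1 `COc1ccc(Cc2nc(NC3=NC(=O)N(C)C3=O)n(C)c2Cc2ccc(OC)cc2)cc1` gives 5080 nM in a functional assay on MCF7 cells (Homo sapiens) for inhibition, read by MTT assay, with a stated time of 96 h; on this read-out higher numbers stand for weaker inhibition and lower numbers for stronger inhibition.
Compound 2 `COc1ccc(Cc2c(Cc3cc(OC)c(O)c(OC)c3)nc(NC3=NC(=O)N(C)C3=O)n2C)cc1` gives 29900 nM in this assay.
Compound 3 `COc1ccc(Cc2c(C(OC)c3ccc(OC)cc3)nc(N)n2C)cc1` gives 22700 nM in this assay.

Compound 2 holds the highest number of the three in this assay. For the measured compounds named here, its nearest neighbour is compound 3, whose number sits within the scatter of that of compound 2; the one step that touches compound 2 is a 5.9-fold higher number from compound 1 to compound 2 (0.77 log units; beyond the scatter), and it lies beyond the scatter.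

Compound 4 `COc1ccc(Cc2c(Cc3cc(OC)c(O)c(OC)c3)nc(N)n2C)cc1` differs from compound 2 by a hydrogen atom in place of a group of 8 heavy atoms (4 carbon, 2 nitrogen, 2 oxygen; one five-membered non-aromatic ring with 2 hetero atoms), on a nitrogen on an aromatic ring. Going by the values given here, no measured pair differs in this way alone, so no measured step bears directly on it. Among the compounds with values here, the only guidance is compound 3, which carries the same free amine on the ring nitrogen and gives 22700 nM in this assay, a number within the scatter of compound 2. The step is therefore expected to be small, a 1.2-fold lower number from compound 2 to compound 4 (0.08 log units; within the scatter), with no clear direction beyond the scatter. Compound 4 is estimated at 25000 nM in this assay, with a range from 8000 nM to 80000 nM.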

Compound 4, half-maximal inhibitory concentration: 16300 nM
The estimate for compound 4 lay 1.5-fold (0.19 log units) above the measured number; low and high end bracket the measured number.
By their numbers in this assay, from the lowest: compound 1; then compounds 4, 3 and 2 (each within the scatter of the next).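

For the compounds shown here, at the nitrogen on an aromatic ring, the first direct reading of this exchange in this assay is a 1.8-fold lower number from compound 2 to compound 4 (0.26 log units; within the scatter), so a hydrogen atom and the group of 8 heavy atoms with its five-membered non-aromatic ring cannot be told apart on this read-out. In this pair, with the 4-hydroxy-3,5-dimethoxyphenyl group in place, the ring-bearing group therefore shows no measurable contribution to the number. No data shown here bear on why the step stays this small.

Going by these compounds, it remains open whether the same exchange would stay within the scatter with the 4-methoxyphenyl group of compound 1, as this single pair cannot show that. Also open, on these data alone, is whether an acetyl group or a longer alkyl chain on that nitrogen would move the number beyond the scatter.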